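This account rests on a few compounds, and the source may have more. Where it says the series, first, only, none or still open, it means among the compounds named here.

The compounds measured so far:

compound 1, `COc1cccc(Nc2cc(Nc3cccc(Cl)c3)ncn2)c1`: in an assay for inhibition of Receptor tyrosine-protein kinase erbB-3 variant L858R (Homo sapiens), read by mobility shift assay, with a stated time of 10 min (on this read-out higher numbers stand for weaker inhibition and lower numbers for stronger inhibition), compound 1 gives 1570 nM
compound 2, `COc1ccc(OC)c(Nc2cc(NC(=O)CCCC(=O)O)ncn2)c1`: in this assay compound 2 gives > 10000 nM, which is a limit of the assay and not a number
compound 3, `O=C(O)CCCC(=O)Nc1cc(Nc2ccc(Cl)cc2)ncn1`: in this assay compound 3 gives 1320 nM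

Compound 3 sits at the lower end of the two numbers shown, but the number for compound 1 lies within the usual scatter of it, so the two cannot be told apart. Compound 2 stands apart, at the limit (the limit of > 10000 nM in this assay, at which 1 of the 3 values shown sits).

The next compound, compound 4, `COc1cccc(Nc2cc(NC(=O)CCCC(=O)O)ncn2)c1`, has not yet been measured in this assay. It differs from compound 3 in one place: 3-methoxyphenyl in place of 4-chlorophenyl on a nitrogen on an aromatic ring. Going by the values given here, no step between two measured compounds isolates this change, so its size can only be guessed. Compound 1, which also carries a 3-methoxyphenyl group on a nitrogen of the shared core, gives 1570 nM, a number close to that of compound 3. On that basis the step from compound 3 to compound 4 is expected to be small, most likely a modest move toward weaker inhibition, a 1.9-fold higher number from compound 3 to compound 4 (0.28 log units; within the scatter). Compound 4 is therefore estimated to give 2500 nM in this assay, within a range from 900 nM to 8000 nM.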

Compound 4, half-maximal inhibitory concentration: 31 nM
Estimate against measurement, compound 4: 81-fold (1.91 log units) above; the whole stated range lies above it.
By their numbers in this assay, from the lowest: compound 4; then compounds 3 and 1 (each within the scatter of the next). At a limit, above all of these: compound 2.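

In this assay, with the (3-carboxypropyl)carbonyl chain held in place, the group on a nitrogen on an aromatic ring proves decisive: 3-methoxyphenyl in place of 4-chlorophenyl gives a 43-fold lower number from compound 3 to compound 4 (1.63 log units; beyond the scatter). With 3-methoxyphenyl held in place instead, (3-carboxypropyl)carbonyl in place of 3-chlorophenyl gives a 51-fold lower number from compound 1 to compound 4 (1.70 log units; beyond the scatter), so among these compounds neither the chain, present in compound 3, nor the 3-methoxyphenyl group, present in compound 1, gives so low a number without the other. The 3-methoxyphenyl group also tolerates no extra methoxy in this series, as hydrogen in place of methoxy on an aromatic carbon gives an at least 320-fold lower number from compound 2 to compound 4 (2.50 log units; beyond the scatter), a step that starts from a limit and not a number: the limit of > 10000 nM in this assay, at which 1 of the 4 values shown sits.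

The compounds shown leave open whether the carboxylic acid at the end of the chain is needed, which a methyl ester or a primary amide in its place would test, and whether a shorter or longer chain would serve as well. They also leave open how 4-methoxyphenyl, 3-ethoxyphenyl or 3-hydroxyphenyl would compare with 3-methoxyphenyl on the same nitrogen.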